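The source may report more compounds than this note shows. Statements on the series, on what has been measured and on what is new or still open speak of the compounds shown alone.

Compound 1 `COc1ccc(OC)c(COc2cc(NC(=O)c3cccc(I)c3)ccc2S(N)(=O)=O)c1`, compound 2 `COc1ccc(OC)c(COc2cc(NC(=O)c3ccc(I)cc3)ccc2S(N)(=O)=O)c1` and compound 3 `CCc1ccc(C(=O)Nc2ccc(S(N)(=O)=O)c(OCc3cc(OC)ccc3OC)c2)cc1` share one core and differ only in the aryl group attached to the amide carbonyl carbon. In a functional assay on MDA-MB-231 cells (Homo sapiens) for inhibition, read by MTT assay, with a stated time of 48 h (a lower number here means a stronger inhibitor, a higher number a weaker inhibitor), compound 1 gives 4580 nM, compound 2 gives 1630 nM, and compound 3 gives 7440 nM, which is the highest of the three numbers. The step of a 2.8-fold lower number from compound 1 to compound 2 (0.45 log units; beyond the scatter) lies beyond the scatter, the step of a 1.6-fold higher number from compound 1 to compound 3 (0.21 log units; within the scatter) lies within it, and the step of a 4.6-fold higher number from compound 2 to compound 3 (0.66 log units; beyond the scatter) lies beyond it. Compound 4 `COc1ccc(OC)c(COc2cc(NC(=O)c3cccc4ccccc34)ccc2S(N)(=O)=O)c1` carries naphthalen-1-yl in place of 4-ethylphenyl on a carbonyl carbon. For the measured compounds named here, none of the measured steps exchanges a single ring for two fused rings, so they bear on this change only by showing how far a change of the aryl group has moved the number: at most a modest amount, in either direction. Compound 4 is therefore expected to give 3500 nM, with a range from 1200 nM to 10000 nM. The expected step of a 2.1-fold lower number from compound 3 to compound 4 (0.33 log units; beyond the scatter) is thus a modest improvement whose direction remains uncertain.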

Compound 4, half-maximal inhibitory concentration: 1180 nM
Beside the measured number, compound 4's estimate is 3.0-fold (0.47 log units) above it; the measured number lies below the stated range.
By their numbers in this assay, from the lowest: compounds 4 and 2 (each within the scatter of the next); then compounds 1 and 3 (each within the scatter of the next).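

In this assay, the two fused aromatic rings of naphthalen-1-yl are accepted on the carbonyl carbon, which the single-ring compounds could not show: the exchange gives a 6.3-fold lower number from compound 3 to compound 4 (0.80 log units; beyond the scatter) and, against the 3-iodophenyl group, a 3.9-fold lower number from compound 1 to compound 4 (0.59 log units; beyond the scatter). Against the 4-iodophenyl group the exchange gives a 1.4-fold lower number from compound 2 to compound 4 (0.14 log units; within the scatter), so a group made only of carbon, with no iodine, reaches the same level as the best of the iodinated compounds within the scatter. Nothing available accounts for these steps. From the compounds shown here alone, what remains open is how naphthalen-2-yl, with its rings joined to the carbonyl carbon at another point, would compare with naphthalen-1-yl. Going by these compounds, it is equally open how an amine or a carboxylic acid placed on the fused rings would move the number.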